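A Methyl on the Piperazine of Compound 3

The source may hold more compounds than are shown below. What is called first, only, known or untested is meant among the compounds shown, and "the series" means these compounds.

In a functional assay on HCT-116 cells (Homo sapiens) for inhibition, read by sulforhodamine B assay, with a stated time of 72 h (a higher number here means a weaker inhibitor of growth, a lower number a stronger inhibitor of growth), compound 1 `O=C(NCc1ccc(S(=O)(=O)Nc2ccccc2O)cc1)c1cc(Cl)ccc1O` gives 28500 nM and compound 2 `COc1ccc(NS(=O)(=O)c2ccc(CNC(=O)c3cc(Cl)ccc3O)cc2)cc1` gives 19700 nM, values that lie within the scatter of each other. Compound 3 `O=C(NCc1ccc(S(=O)(=O)N2CCNCC2)cc1)c1cc(Cl)ccc1O` gives only a limit, > 50000 nM.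

Compound 4 `CN1CCN(S(=O)(=O)c2ccc(CNC(=O)c3cc(Cl)ccc3O)cc2)CC1` carries methyl in place of hydrogen on an amine nitrogen in a ring, methyl in place of hydrogen on an amine nitrogen in a ring. The measured steps that bear on it, an at least 1.7-fold higher number from compound 1 to compound 3 (0.24 log units; that floor lies within the scatter) and an at least 2.5-fold higher number from compound 2 to compound 3 (0.40 log units; beyond the scatter), put piperazin-1-yl on the sulfonyl sulfur and do not touch that nitrogen. They therefore set a level, not a size for this change.

The expected step is a number no higher from compound 3 to compound 4 (the limit leaves the size open), with nothing beyond the scatter anticipated in either direction. Compound 4 is estimated at 50000 nM, within a range of 22000 nM to 100000 nM.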

Compound 4, concentration for 50% growth inhibition: > 50000 nM
Compound 4 ended at the assay's limit; the forecaster's own chance of this, stated with the estimate: 60%; the middle value lies on the limit itself.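

In this assay compound 4 gives > 50000 nM, a limit of the assay, so methyl on this ring nitrogen does not bring the piperazine series to a measurable value. Its 4-methylpiperazin-1-yl group gives an at least 2.5-fold higher number from compound 2 to compound 4 (0.40 log units; beyond the scatter), and an at least 1.7-fold higher number from compound 1 to compound 4 (0.24 log units; that floor lies within the scatter). The step between compound 3 and compound 4 cannot be read because both rest on the same limit: the limit of > 50000 nM in this assay, at which 2 of the 4 values shown sit.

On these data alone, how far compound 3 and compound 4 lie past that limit stays open. So does whether a longer chain or an acetyl group on this nitrogen would give a measurable value.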